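The source may report more compounds than this note shows. Statements on the series, on what has been measured and on what is new or still open speak of the compounds shown alone.

Compound 1 `Clc1cc2nc(Cl)n(Cc3ccccc3)c2cc1Cl` in a functional assay on KB cells (Homo sapiens) for inhibition (on this read-out lower numbers stand for stronger inhibition and higher numbers for weaker inhibition), gives only a limit, > 100000 nM.
Compound 2 `Clc1ccc(Cn2c(Cl)nc3cc(Cl)c(Cl)cc32)cc1` in this assay gives only a limit, > 100000 nM.

Compound 1 thus stands at the limit (the limit of > 100000 nM in this assay, at which 2 of the 2 values shown sit), with no number of its own. Among the compounds with values here, the one measured step, a step that the two limits leave unreadable from compound 1 to compound 2, is chloro in place of hydrogen on an aromatic carbon and its size cannot be read. Compound 3 `O=[N+]([O-])c1cccc(Cn2c(Cl)nc3cc(Cl)c(Cl)cc32)c1` differs from compound 1 by nitro in place of hydrogen on an aromatic carbon. No measured step bears on this change, so no direction beyond the scatter can be read from the shown values. The expected step is a number no higher from compound 1 to compound 3 (the limit leaves the size open), little change. The estimate for compound 3 in this assay is 100000 nM, within 20000 nM to 500000 nM.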

Compound 3, half-maximal inhibitory concentration: 239000 nM
The estimate for compound 3 lay 2.4-fold (0.38 log units) below the measured number; the range from low to high includes it.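

No new step can be read between compound 1 and compound 3, since compound 1 gives only a limit: the limit of > 100000 nM in this assay, at which 2 of the 3 values shown sit. Going by these compounds, whether nitro in place of hydrogen on an aromatic carbon changes the number in this assay stays open.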